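The compounds below may be only part of what the source reports. "The series", "measured", "known", "first", "only" and "open" are said of these compounds alone.

Of the compounds shown here, three have been tested in a functional assay on 786-0 cells (Homo sapiens) for inhibition, read by sulforhodamine B assay, with a stated time of 48 h; a higher number here means a weaker inhibitor of growth, a lower number a stronger inhibitor of growth. Compound 1 `COc1ccc(/C=C/C2(C)C=CC(=O)O2)c(OC)c1OC` gives 132000 nM in this assay. Compound 2 `COc1c(O)ccc(/C=C/C2(C)C=CC(=O)O2)c1OC` gives 109000 nM, and compound 3 `CC1(/C=C/c2ccc(O)cc2)C=CC(=O)O1` gives 143000 nM. All three of these numbers lie within the usual scatter of one another, so none of them can be set apart as a stronger or weaker inhibitor of growth.

Compound 1 and compound 2 differ in a single place: methyl in place of hydrogen on an oxygen on an aromatic ring. That change gave a 1.2-fold higher number from compound 2 to compound 1 (0.08 log units; within the scatter), a step that falls inside the scatter.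

Compound 4 `COc1ccc(/C=C/C2(C)C=CC(=O)O2)cc1` has not been measured yet. It differs from compound 3 in the same way: methyl in place of hydrogen on an oxygen on an aromatic ring. The difference between the core of compound 3 and the core of compound 2 is not broken down here.

Because the matching change from compound 2 to compound 1 produced only a 1.2-fold higher number from compound 2 to compound 1 (0.08 log units; within the scatter), the expected step from compound 3 to compound 4 in this assay is a 1.0-fold higher number from compound 3 to compound 4 (0.02 log units; within the scatter). Compound 4 is therefore estimated to give 150000 nM, most likely between 75000 nM and 300000 nM.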

Compound 4, concentration for total growth inhibition: > 1000000 nM
Compound 4: only a limit was reported; the forecaster's own chance of this, stated with the estimate: 10%; middle value at least 6.6-fold (0.82 log units) away from the limit.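

In this assay, methyl in place of hydrogen on an oxygen on an aromatic ring gave an at least 6.9-fold higher number from compound 3 to compound 4 (0.84 log units; beyond the scatter), so this change did not carry over with the same size from one core to the other: the same change on two cores in this assay, a 1.2-fold higher number (0.08 log units; within the scatter) from compound 2 to compound 1 and an at least 6.9-fold higher number (0.84 log units; beyond the scatter) from compound 3 to compound 4, at least 5.7-fold (0.76 log units) apart, beyond the scatter of two such steps

The value of compound 4, > 1000000 nM, is a limit of the assay and not a number: the limit of > 1000000 nM in this assay, at which 1 of the 4 values shown sits.

Among the compounds shown here, these results show that a step seen on one core was a poor guide to the same step on the other, but with only two pairs they cannot show which feature of the two cores accounts for the gap, or how the change would behave on a third core.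

On these data alone, it remains open whether the hydroxy group on the core of compound 3 could be replaced by an amine, or its hydrogen by a longer chain such as ethyl, and how these would compare with methyl. As far as these compounds go, the same two replacements also remain open on the core of compound 2, where they would show whether that core again gives only a small step.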